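The compounds below may be only part of what the source reports. "The series", "measured", "known", "first", "only" and "open" are said of these compounds alone.

Working notes on the series. Compound 1 `Cn1c(-c2ccccc2Cl)cnc1NC(=O)c1ncc[nH]1` and compound 2 `Cn1c(-c2ccccc2Cl)cnc1NC(=O)c1ccc(F)cc1` share a core and the same methyl-bearing ring; compound 3 `COc1ccc(-c2cnc(NC(=O)c3ccco3)n2C)cc1` differs on both sides of the core. In a toxicity assay on THP-1 cells (Homo sapiens) for inhibition (on this read-out lower numbers stand for higher toxicity in this test and higher numbers for lower toxicity in this test), compound 1 gives only a limit of the assay, > 50000 nM. In this assay compound 2 likewise gives only a limit, > 50000 nM. In this assay compound 3 gives only a limit, > 100000 nM. Among the compounds with values here, the one step between measured neighbours, a step that the two limits leave unreadable from compound 1 to compound 2, is unreadable because both of its ends are limits. Compound 2 thus stands at the limit of > 50000 nM in this assay, at which 2 of the 3 values shown sit, and nothing measured sets it apart from the other two values; the remaining value sits at the limit of > 100000 nM in this assay, at which 1 of the 3 values shown sits.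

Within the data shown here, compound 4 `Cn1c(-c2cccc(F)c2)cnc1NC(=O)c1ccc(F)cc1` is not yet measured. 3-fluorophenyl in place of 2-chlorophenyl on an aromatic carbon The only measured step alters the group on the carbonyl carbon, not the aromatic carbon changed here, and its size cannot be read, so no measured step bears directly on the change to compound 4. With every value in the series at a limit, no step beyond the scatter is expected in this assay, and the estimated step that the limit leaves unreadable from compound 2 to compound 4 is taken as flat. Compound 4 is expected to give about 70000 nM, within a range of 30000 nM to 150000 nM, most probably reported again only as a limit.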

Compound 4, half-maximal cytotoxic concentration: 58000 nM
The estimate for compound 4 lay 1.2-fold (0.08 log units) above the measured number, and the stated range covers the measured number.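

No step can be read from compound 2 to compound 4. In this assay compound 2 gives > 50000 nM as a limit of the assay, not a number. The compounds shown leave open how 3-fluorophenyl compares with 2-chlorophenyl on the shared core when both ends carry numbers, and whether either group shifts the read-out beyond the usual scatter.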